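The source may report more compounds than this note shows. Statements on the series, on what has been measured and on what is new or still open speak of the compounds shown alone.

Of the compounds shown here, three sharing one core have been tested in a functional assay on HCT-116 cells (Homo sapiens) for antiproliferative activity, read by MTT assay, with a stated time of 48 h; a lower number here means a stronger inhibitor, a higher number a weaker inhibitor. Compound 1 `N#CC1=C(N)Oc2c(c3nc4ccccc4nc3c3ccccc23)C12C(=O)N(Cc1cnnn1-c1ccccc1Cl)c1ccccc12` gives > 50000 nM, which is a limit of the assay rather than a number. Compound 2 `N#CC1=C(N)Oc2c(c3nc4ccccc4nc3c3ccccc23)C12C(=O)N(Cc1cnnn1-c1cccc(Cl)c1)c1ccccc12` likewise gives > 50000 nM, again only a limit. The step that the two limits leave unreadable from compound 1 to compound 2 therefore cannot be read. Within the data shown here, compound 3 `N#CC1=C(N)Oc2c(N)cc3nc4ccccc4nc3c2C12C(=O)N(Cc1cnnn1-c1ccccc1Br)c1ccccc12` gives 12400 nM, the only number among the three; the rest is the limit of > 50000 nM in this assay, at which 2 of the 3 values shown sit. Compound 4 `CCc1cccc(CC)c1-n1nncc1CN1C(=O)C2(C(C#N)=C(N)Oc3c(N)cc4nc5ccccc5nc4c32)c2ccccc21` carries 2,6-diethylphenyl in place of 2-bromophenyl on an aromatic nitrogen. Among the measured compounds shown here, no measured step touches this position with a comparable change, and the one measured step is unreadable, so nothing points to a shift beyond the usual scatter in either direction. Compound 4 is therefore expected close by, at 12000 nM with a range from 5000 nM to 50000 nM. The step of a 1.0-fold lower number from compound 3 to compound 4 (0.01 log units; within the scatter) is expected to stay within the scatter.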

Compound 4, half-maximal inhibitory concentration: 37600 nM
Beside the measured number, compound 4's estimate is 3.1-fold (0.50 log units) below it; the measured number falls inside the stated range.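

Among these compounds, this is the first readable step at this position, on an aromatic nitrogen: in this assay, the change brings a 3.0-fold higher number from compound 3 to compound 4 (0.48 log units; beyond the scatter). The group on this nitrogen therefore does affect the read-out, and 2,6-diethylphenyl weakens activity relative to 2-bromophenyl without abolishing it, as compound 4 still gives a number rather than a limit. Nothing shown accounts for this step.

Going by these compounds, how a plain phenyl, or a phenyl bearing a single ethyl group or an amine, would read here stays open. So does whether losing the bromine or gaining the ethyl groups carries the step.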